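A Hydroxy for Bromo Swap on One Shared Core

A few compounds are considered here, and "the series" means these few. Any claim that something is new, unique, unknown or untested is made for them only; others in the source may bear on it.

Of the compounds shown here, three built on the same core have been tested in a functional assay on MCF7 cells (Homo sapiens) for antiproliferative activity, read by MTT assay, with stated times of 24 h and 72 h; on this read-out lower numbers stand for stronger inhibition and higher numbers for weaker inhibition. Compound 1 `COc1cc(N2C(=O)[C@@H](Oc3ccccc3)[C@H]2c2ccc(Br)cc2)cc(OC)c1OC` gives 48000 nM, the second highest of the three numbers. Compound 2 `COc1cc(N2C(=O)[C@@H](Oc3ccccc3)[C@H]2c2cccc3ccccc23)cc(OC)c1OC` gives 53000 nM, and the difference a 1.1-fold higher number from compound 1 to compound 2 (0.04 log units; within the scatter) lies within the usual scatter, so these two cannot be told apart. Compound 3 `COc1cc(N2C(=O)[C@@H](Oc3ccccc3)[C@H]2c2ccc([S+](C)[O-])cc2)cc(OC)c1OC` gives 20000 nM, a modest step beyond the scatter in a 2.4-fold lower number from compound 1 to compound 3 (0.38 log units; beyond the scatter) and likewise in a 2.7-fold lower number from compound 2 to compound 3 (0.42 log units; beyond the scatter).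

Compound 4 `COc1cc(N2C(=O)[C@@H](Oc3ccccc3)[C@H]2c2ccc(O)cc2)cc(OC)c1OC` has not yet been measured. It differs from compound 1 by hydroxy in place of bromo on an aromatic carbon. Among the measured compounds shown here, the only measured step at the same place is a 2.4-fold lower number from compound 1 to compound 3 (0.38 log units; beyond the scatter), where a different group replaced bromine and the number fell modestly. For the measured compounds named here, no measured compound carries a hydroxy group, so the expectation rests on that single precedent alone. The expected step is a 1.6-fold lower number from compound 1 to compound 4 (0.20 log units; within the scatter), a modest lowering at most, possibly nothing beyond the scatter. Compound 4 is therefore expected to give about 30000 nM in this assay, with a likely range from 12000 nM to 80000 nM.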

Compound 4, half-maximal inhibitory concentration: 48000 nM
Estimate against measurement, compound 4: 1.6-fold (0.20 log units) below; low and high end bracket the measured number.
By their numbers in this assay, from the lowest: compound 3; then compounds 1, 4 and 2 (each within the scatter of the next).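

Replacing bromo with hydroxy on this aromatic carbon leaves the number unmoved in this assay (no change at the digits printed from compound 1 to compound 4 (within the scatter)), and compound 4 also cannot be told apart from the naphthalen-1-yl compound (a 1.1-fold lower number from compound 2 to compound 4 (0.04 log units; within the scatter)). So far, then, exchanging bromine for another group does not by itself lower the number, and the sulfur-bearing group of compound 3 remains the only one here that does (a 2.4-fold higher number from compound 3 to compound 4 (0.38 log units; beyond the scatter)). Nothing measured here offers an explanation for these results.

The compounds shown leave open whether an amine, a carboxylic acid or a methoxy group at this place would read like hydroxy and bromo or like the sulfur-bearing group. They also do not show whether a longer chain carrying sulfur would lower the number further.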